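The source may report more compounds than this note shows. Statements on the series, on what has been measured and on what is new or still open speak of the compounds shown alone.

In a functional assay on CCRF-CEM cells (Homo sapiens) for cytotoxicity (on this read-out higher numbers stand for weaker inhibition and lower numbers for stronger inhibition), compound 1 (`Nc1ccn([C@@H]2C=C(F)[C@H](CO)O2)c(=O)n1`) gives > 100000 nM, which is a limit and not a number. Compound 2 (`Cc1cn([C@@H]2C=C(F)[C@H](CO)O2)c(=O)nc1O`) gives > 100000 nM, also a limit. Compound 3 (`Cc1cn([C@H]2C=C(F)[C@H](CO)O2)c(=O)nc1O`) gives > 100000 nM, again a limit. Compound 2 therefore has no number of its own on this read-out, and its standing comes down to the limit of > 100000 nM in this assay, at which 3 of the 3 values shown sit.

Compound 4 (`O=c1nc(O)ccn1[C@@H]1C=C(F)[C@H](CO)O1`) departs from compound 2 by hydrogen in place of methyl on an aromatic carbon, ortho to a hydroxy group.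

Going by the values given here, only one measured step touches compound 2, namely a step that the two limits leave unreadable from compound 2 to compound 3. That step reflects (the fact that compounds 2 and 3 differ only in the configuration as drawn), so it does not involve the methyl at all, and it has no readable size. The data thus offer no measured size for this change and no direction for it. Among the compounds with values here, with every value so far at the same limit, no step beyond the scatter can be argued for in this assay, and compound 4 is expected to remain inactive at the top of the range tested.

The step this expectation implies is estimated as a number no higher from compound 2 to compound 4 (the limit leaves the size open). For compound 4 the expected value is 100000 nM, with an estimated range of 40000 nM to 200000 nM.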

Compound 4, half-maximal inhibitory concentration: 30100 nM
Estimate against measurement, compound 4: 3.3-fold (0.52 log units) above, outside the stated range (below it).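

In this assay, going by these compounds alone, hydrogen in place of methyl on the aromatic carbon ortho to a hydroxy group gives an at least 3.3-fold lower number from compound 2 to compound 4 (0.52 log units; beyond the scatter), so this position is the first place where a change can be seen to register on the read-out. A second single change to the same core, hydroxy in place of amino on an aromatic carbon, gives an at least 3.3-fold lower number from compound 1 to compound 4 (0.52 log units; beyond the scatter), which means that compound 4 stands apart from both of its neighbours and not just from the methyl compound. Compound 4 is also the only compound shown with a number of its own, while the others remain at a limit: the limit of > 100000 nM in this assay, at which 3 of the 4 values shown sit.

As far as these compounds go, each of the two steps starts from a limit, and the full size of both stays open. The step between the two stereoisomers, compound 2 and compound 3, cannot be read, and the compounds shown do not tell whether configuration matters once the methyl has gone. They also leave open how an ethyl group or a chlorine atom on this aromatic carbon would compare with the hydrogen of compound 4.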